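The source may report more compounds than this note shows. Statements on the series, on what has been measured and on what is new or still open speak of the compounds shown alone.

In a functional assay on DU-145 cells (Homo sapiens) for cytotoxicity, read by MTT assay (a lower number here means a stronger inhibitor, a higher number a weaker inhibitor), compound 2 `CC(C)=CC[C@@H](OC(=O)C1CCOC1)C1=CC(=O)c2c(O)ccc(O)c2C1=O` gives 47500 nM. Compound 3 `COCCO[C@H](CC=C(C)C)C1=CC(=O)c2c(O)ccc(O)c2C1=O` gives 43200 nM in this assay, and the two numbers sit within the scatter of each other, so compound 2 stands apart from nothing here. Compound 1 `CC(C)=CC[C@@H](OC(=O)CC(C)(O)c1ccccc1)C1=CC(=O)c2c(O)ccc(O)c2C1=O` reaches only the assay limit of > 100000 nM. Compound 4 `CCCCC(C)(O)CC(=O)O[C@H](CC=C(C)C)C1=CC(=O)c2c(O)ccc(O)c2C1=O` differs from compound 2 by 2-hydroxy-2-methylhexyl in place of oxolan-3-yl on a carbonyl carbon. The step that bears on this is an at least 2.1-fold lower number from compound 1 to compound 2 (0.32 log units; beyond the scatter), where 2-hydroxy-2-phenylpropyl gave way to oxolan-3-yl; compound 4 brings back a hydroxy-bearing chain, 2-hydroxy-2-methylhexyl, so the step is expected to run the other way, toward a higher number, a 1.8-fold higher number from compound 2 to compound 4 (0.25 log units; within the scatter). The estimate for compound 4 is 85000 nM, between 35000 nM and 210000 nM.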

Compound 4, half-maximal inhibitory concentration: 76500 nM
Estimate against measurement, compound 4: 1.1-fold (0.05 log units) above; measured number inside the range.
By their numbers in this assay, from the lowest: compounds 3, 2 and 4 (each within the scatter of the next). At a limit, above all of these: compound 1.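

At this carbonyl carbon, the step from the oxolan-3-yl ring to the open 2-hydroxy-2-methylhexyl chain, with its hydrogen-bond donor, in this assay is a 1.6-fold higher number from compound 2 to compound 4 (0.21 log units; within the scatter), so the two cannot be told apart. The same holds when it is set against the 2-methoxyethyl group on the oxygen on a saturated carbon (a 1.8-fold higher number from compound 3 to compound 4 (0.25 log units; within the scatter)). With butyl in place of phenyl, the step is an at least 1.3-fold lower number from compound 1 to compound 4 (0.11 log units; that floor lies within the scatter). That step gives only a floor, because compound 1 stands at a limit: the limit of > 100000 nM in this assay, at which 1 of the 4 values shown sits. As far as these compounds go, whether an amine or a carboxylic acid on this carbonyl carbon would move the number beyond the scatter stays open.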